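The compounds below may be only part of what the source reports. "The series", "measured", "known", "first", "only" and "open" are said of these compounds alone.

Compound 1 `CSc1ccc(-c2nc3c(=O)n(C)c(=O)n(C)c3[nH]2)cc1` and compound 2 `Cn1c(=O)c2nc(-c3ccc(-c4ccccc4)cc3)[nH]c2n(C)c1=O` share one core and differ only at an aromatic carbon of the outer ring. In an assay for binding affinity to adenosine receptor A1 (Bos taurus) (a lower number here means a stronger inhibitor, a higher number a weaker inhibitor), compound 1 gives 2 nM, and compound 2 gives 3.5 nM. For the measured compounds named here, the single step that links them, a 1.8-fold higher number from compound 1 to compound 2 (0.24 log units; within the scatter), puts phenyl in place of methylsulfanyl, and the two numbers lie within the scatter of each other, so compound 2 stands alongside compound 1 rather than apart from it.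

Compound 3 `CCc1ccc(-c2nc3c(=O)n(C)c(=O)n(C)c3[nH]2)cc1` is not yet measured. It differs from compound 2 by the change (ethyl in place of phenyl on an aromatic carbon), ethyl in place of phenyl on an aromatic carbon of a six-membered aromatic ring of carbon only, para to a large group. Going by the values given here, the one measured step at this position, a 1.8-fold higher number from compound 1 to compound 2 (0.24 log units; within the scatter), was within the scatter, which suggests that this aromatic carbon tolerates groups of quite different size without a clear effect in this assay. The expected step of a 1.2-fold lower number from compound 2 to compound 3 (0.07 log units; within the scatter) is therefore none beyond the scatter. Compound 3 is estimated at 3 nM, with a range from 1 nM to 10 nM.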

Compound 3, half-maximal inhibitory concentration: 0.8 nM
Beside the measured number, compound 3's estimate is 3.8-fold (0.57 log units) above it, outside the stated range (below it).
By their numbers in this assay, from the lowest: compound 3; then compounds 1 and 2 (each within the scatter of the next).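

In this assay this aromatic carbon proves responsive to the group it carries: ethyl in place of phenyl gives a 4.4-fold lower number from compound 2 to compound 3 (0.64 log units; beyond the scatter), and ethyl in place of methylsulfanyl gives a 2.5-fold lower number from compound 1 to compound 3 (0.40 log units; beyond the scatter), two modest steps beyond the scatter. For the compounds shown here, the only earlier step at this position lay within the scatter, so the apparent tolerance seen with compound 1 and compound 2 does not extend to every group placed here. Ethyl, with 2 heavy atoms and no ring, gives the lowest number of the three, while phenyl, with 6 heavy atoms and one ring, remains within the scatter of methylsulfanyl.

Nothing at hand explains why ethyl separates from the other two groups. The compounds shown leave open whether a longer chain such as propyl, an amine or a carboxylic acid at this aromatic carbon would stand with ethyl or with phenyl and methylsulfanyl, and whether ethyl would keep its advantage on a different core.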